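This account rests on a few compounds, and the source may have more. Where it says the series, first, only, none or still open, it means among the compounds named here.

Compound 1 `O=C(c1cccnc1)c1cc2c(-c3cccnc3)nn(-c3ccccc3)c2[nH]c1=O`: in a functional assay on MCF7 cells (Homo sapiens) for cytotoxicity, read by sulforhodamine B assay (a higher number here means a weaker inhibitor, a lower number a stronger inhibitor), compound 1 gives 10.1 ug/mL.
Compound 2 `O=C(c1ccc(Cl)cc1)c1cc2c(-c3cccnc3)nn(-c3ccccc3)c2[nH]c1=O`: compound 2 gives 6.45 ug/mL.
Compound 3 `N#Cc1cc2c(-c3cccnc3)nn(-c3ccccc3)c2[nH]c1=O`: compound 3 gives 3 ug/mL.

Compound 3 has the lowest number of the three, and both steps leading to it, a 3.4-fold lower number from compound 1 to compound 3 (0.53 log units; beyond the scatter) and a 2.2-fold lower number from compound 2 to compound 3 (0.33 log units; beyond the scatter), lie beyond the scatter. Compound 4 `O=C(c1ccc(F)cc1)c1cc2c(-c3cccnc3)nn(-c3ccccc3)c2[nH]c1=O` differs from compound 3 by (4-fluorophenyl)carbonyl in place of cyano on an aromatic carbon. This change largely reverses the one behind a 2.2-fold lower number from compound 2 to compound 3 (0.33 log units; beyond the scatter), with a 4-fluorophenyl ring instead of a 4-chlorophenyl ring on the carbonyl; the step of a 1.6-fold lower number from compound 1 to compound 2 (0.19 log units; within the scatter) suggests that changing the ring on that carbonyl shifts the number only a little. In this assay the number for compound 4 is therefore expected to go up, by roughly a 2.2-fold higher number from compound 3 to compound 4 (0.34 log units; beyond the scatter). Compound 4 is estimated at 6.5 ug/mL, most likely between 3.5 ug/mL and 12 ug/mL.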

Compound 4, half-maximal inhibitory concentration: 8.7 ug/mL
Compound 4: the middle estimate sits 1.3-fold (0.13 log units) below what was measured; measured number inside the range.
By their numbers in this assay, from the lowest: compound 3; then compounds 2, 4 and 1 (each within the scatter of the next).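

In this assay, a third carbonyl-linked ring on this aromatic carbon again ends up beyond the scatter from cyano, with a 2.9-fold higher number from compound 3 to compound 4 (0.46 log units; beyond the scatter). The ring itself matters little here: fluoro in place of chloro gives a 1.3-fold higher number from compound 2 to compound 4 (0.13 log units; within the scatter) and 4-fluorophenyl in place of pyridin-3-yl gives a 1.2-fold lower number from compound 1 to compound 4 (0.06 log units; within the scatter), both within the scatter, so compounds 1, 2 and 4 cannot be ranked. Nothing available explains the gap between cyano and these carbonyl groups.

Going by these compounds, whether an amine or a carboxylic acid on this aromatic carbon would give a number nearer compound 3 or compound 4 remains open.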